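Urea series on SNB-19 growth: dropping one trifluoromethyl

The source may hold more compounds than are shown below. What is called first, only, known or untested is meant among the compounds shown, and "the series" means these compounds.

Measured so far in a functional assay on SNB-19 cells (Homo sapiens) for inhibition, read by sulforhodamine B assay, with a stated time of 48 h; on this read-out higher numbers stand for weaker inhibition of growth and lower numbers for stronger inhibition of growth:
- Compound 1, `O=C(Nc1cccc(-n2cc(-c3ccncc3)c(-c3ccc(Cl)c(O)c3)n2)c1)Nc1ccc(Cl)c(Cl)c1`, gives only a limit, > 32500 nM.
- Compound 2, `O=C(Nc1cccc(-n2cc(-c3ccncc3)c(-c3ccc(Cl)c(O)c3)n2)c1)Nc1cc(C(F)(F)F)cc(C(F)(F)F)c1`, gives 8960 nM.
- Compound 3, `COc1cc(-c2nn(-c3cccc(NC(=O)c4ccccc4)c3)cc2-c2ccncc2)ccc1Cl`, gives only a limit, > 100000 nM.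

For the measured compounds named here, compound 2 is the single compound with a number in this assay; the other two values are limits of the assay, one at the limit of > 100000 nM in this assay, at which 1 of the 3 values shown sits, and one at the limit of > 32500 nM in this assay, at which 1 of the 3 values shown sits. Going by the values given here, no step between measured compounds that differ in one place is available, so nothing shows how a change on the urea ring moves the read-out.

Compound 4, `O=C(Nc1cccc(-n2cc(-c3ccncc3)c(-c3ccc(Cl)c(O)c3)n2)c1)Nc1cccc(C(F)(F)F)c1`, differs from compound 2 by hydrogen in place of trifluoromethyl on an aromatic carbon. Among the compounds with values here, with compound 1 at its limit and compound 2 the only number, a step beyond the scatter toward weaker growth inhibition is expected, a 2.8-fold higher number from compound 2 to compound 4 (0.45 log units; beyond the scatter). Compound 4 is estimated at 25000 nM, within 8000 nM to 80000 nM.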

Compound 4, concentration for total growth inhibition: > 32500 nM
Compound 4 gave a limit, no number; the forecaster's own chance of this, stated with the estimate: 40%; middle value at least 1.3-fold (0.11 log units) away from the limit.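

In this assay, for the compounds shown here, hydrogen in place of trifluoromethyl on an aromatic carbon gives an at least 3.6-fold higher number from compound 2 to compound 4 (0.55 log units; beyond the scatter) and is the first readable step, showing that this position responds to the change. Going by these compounds, compound 4 gives > 32500 nM as a limit of the assay and not a number, so the true size of the step stays open on its upper side. The step between compound 1 and compound 4 cannot be read, since both values are limits. Open, on these data alone, is whether a methoxy, a nitrile or an amine on that aromatic carbon would keep a number in this assay or fall to a limit.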